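Compound 1 to compound 4: methyl for fluoro

The source may hold more compounds than are shown below. What is called first, only, known or untested is meant among the compounds shown, and "the series" means these compounds.

In an ADME assay on HEK-293T cells (Homo sapiens) for inhibition, read by CCK-8 assay, with a stated time of 48 h, tested at 20 uM (a lower number here means less inhibition of growth, a higher number more inhibition of growth at the concentration tested), compound 1 (`COc1ccc(S(=O)(=O)Oc2ccccc2/C=C(\C#N)C(=O)Nc2nnc(Cc3ccc(F)cc3)s2)cc1`) gives 20%, the highest of the three measured numbers. Compound 2 (`N#C/C(=C\c1ccccc1OS(=O)(=O)c1ccc([N+](=O)[O-])cc1)C(=O)Nc1nnc(Cc2ccc(F)cc2)s1`) gives 8%, and compound 3 (`N#C/C(=C\c1ccccc1OS(=O)(=O)c1ccc(Cl)cc1)C(=O)Nc1nnc(Cc2ccc(F)cc2)s1`) gives 6%.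

Compound 4 (`COc1ccc(S(=O)(=O)Oc2ccccc2/C=C(\C#N)C(=O)Nc2nnc(Cc3ccc(C)cc3)s2)cc1`) differs from compound 1 by methyl in place of fluoro on an aromatic carbon. This is methyl in place of fluoro on an aromatic carbon, para to a large group, turning 4-fluorobenzyl into 4-methylbenzyl.

The measured steps all change a different group. Both a number 12 percentage points lower from compound 1 to compound 2 (beyond the scatter) and a number 14 percentage points lower from compound 1 to compound 3 (beyond the scatter) are modest, with nitro or chloro in place of methoxy, while a number 2 percentage points lower from compound 2 to compound 3 (within the scatter) stays within the scatter. None of them touches the fluoro group, so the data hold no direct precedent for this change and give only a rough sense of step size among these three compounds.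

No step beyond the scatter is expected in this assay. The estimated step is a number 2 percentage points lower from compound 1 to compound 4 (within the scatter). For compound 4 the estimated value is 18%, with an expected range of 7% to 31%.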

Compound 4, percent growth inhibition at one concentration: 28%
Estimate against measurement, compound 4: 10 percentage points below; low and high end bracket the measured number.
By their numbers in this assay, from the lowest: compounds 3 and 2 (each within the scatter of the next); then compounds 1 and 4 (each within the scatter of the next).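

In this assay, among the compounds shown here, the change from 4-fluorobenzyl to 4-methylbenzyl gives a number 8 percentage points higher from compound 1 to compound 4 (within the scatter), the first reading at this end of the molecule, since all earlier steps changed the methoxy group on the other aromatic ring. With methoxy held in place, methyl in place of fluoro on this aromatic carbon therefore does not separate compound 4 from compound 1, and this single pair is all the support for that reading. Nothing at hand explains the size of this step.

Going by these compounds, it remains open whether a group of a different kind at this position, such as an amine, a carboxylic acid or a longer alkyl chain, would move the number beyond the scatter. Also open, on these data alone, is whether methyl in place of fluoro reads the same when nitro or chloro stands in place of methoxy.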